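A 1,3-benzoxazol-2-yl in place of 1H-benzimidazol-2-yl

A few compounds are considered here, and "the series" means these few. Any claim that something is new, unique, unknown or untested is made for them only; others in the source may bear on it.

Values in a functional assay on HL-60 cells (Homo sapiens) for antiproliferative activity, read by MTT assay, with a stated time of 48 h; a lower number here means a stronger inhibitor, a higher number a weaker inhibitor:
Compound 1 `CCCn1c(N)c(-c2nc3ccccc3[nH]2)c2nc(C#N)c(C#N)nc21`: 45200 nM
Compound 2 `CN(C)CCCn1c(N)c(-c2nc3ccccc3[nH]2)c2nc(C#N)c(C#N)nc21`: 870 nM
Compound 3 `CCN(CC)CCCn1c(N)c(-c2nc3ccccc3[nH]2)c2nc(C#N)c(C#N)nc21`: > 730 nM (a limit)

Of the two actual numbers, compound 2 holds the lower, at 870 nM. Compound 3 gives only a limit, > 730 nM. That leaves a step that the limit leaves unreadable from compound 2 to compound 3.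

Compound 4 `CN(C)CCCn1c(N)c(-c2nc3ccccc3o2)c2nc(C#N)c(C#N)nc21` alters compound 2 in one place: 1,3-benzoxazol-2-yl in place of 1H-benzimidazol-2-yl on an aromatic carbon. The 3-(dimethylamino)propyl group stays. Among the measured compounds shown here, no measured step touches the position that changes. For the measured compounds named here, the one readable step, a 52-fold lower number from compound 1 to compound 2 (1.72 log units; beyond the scatter), is large, but it lies in the chain that compound 4 keeps, so it sets no size for this change. With nothing measured to suggest otherwise, no step beyond the scatter is expected in this assay, though a slightly higher number would not surprise. The expected change is a 1.4-fold higher number from compound 2 to compound 4 (0.14 log units; within the scatter). For compound 4 the estimated value is 1200 nM, with an expected range from 300 nM to 5000 nM.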

Compound 4, half-maximal inhibitory concentration: 390 nM
The estimate for compound 4 lay 3.1-fold (0.49 log units) above the measured number; measured number inside the range.
By their numbers in this assay, from the lowest: compound 4; then compound 2; then compound 1.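

In this assay, the 1,3-benzoxazol-2-yl in place of 1H-benzimidazol-2-yl gives a 2.2-fold lower number from compound 2 to compound 4 (0.35 log units; beyond the scatter), a modest step that shows this aromatic carbon also affects the read-out, whereas the earlier readable step lay in the chain. The exchange keeps the count of heavy atoms and the ring types, while the entering group has no hydrogen-bond donor and one more hydrogen-bond acceptor, so the activity survives the loss of the benzimidazole hydrogen on the ring nitrogen. Nothing measured here explains why the number falls.

Going by these compounds, whether a 1,3-benzothiazol-2-yl or a plain phenyl at this position would move the number further remains open. So does whether the 1,3-benzoxazol-2-yl gives a similar step alongside a longer amine chain or a morpholine in place of the dimethylamino group.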